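A few compounds are considered here, and "the series" means these few. Any claim that something is new, unique, unknown or untested is made for them only; others in the source may bear on it.

Measured values in an ADME assay on MRC5 cells (Homo sapiens) for cytotoxicity; a lower number here means that less compound is tolerated, a higher number that more compound is tolerated:
Compound 1 `Cc1cn([C@@H]2C[C@H](O)[C@@H](CNC(=O)Nc3ccc(C(C)(C)C)cc3)O2)c(=O)[nH]c1=O` gives > 50000 nM, which is a limit of the assay and not a number.
Compound 2 `Cc1cn([C@@H]2C[C@H](O)[C@@H](CNC(=O)Nc3ccc(Cl)c(C(F)(F)F)c3)O2)c(=O)[nH]c1=O` gives > 50000 nM, again a limit of the assay.
Compound 3 `Cc1cn([C@@H]2C[C@H](O)[C@@H](CNC(=O)Nc3cccc(COc4ccccc4)c3)O2)c(=O)[nH]c1=O` gives > 50000 nM, again a limit of the assay.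

Compound 1 therefore stands at the top limit of this assay, and the same holds for the other two: the limit of > 50000 nM in this assay, at which 3 of the 3 values shown sit. Among the measured compounds shown here, no value in the set is a number, so no order among the three can be drawn and no measured step exists to set a scale for a change in the aryl urea part of the shared core.

Compound 4 `Cc1cn([C@@H]2C[C@H](O)[C@@H](CNC(=O)Nc3ccc(-c4ccc(C(F)(F)F)nc4)cc3)O2)c(=O)[nH]c1=O` differs from compound 1 as follows: 6-(trifluoromethyl)pyridin-3-yl in place of tert-butyl on an aromatic carbon. Since every measured compound, whatever its aryl substitution, returns only the limit, no movement beyond the scatter is expected for the step of a number no higher from compound 1 to compound 4 (the limit leaves the size open). Compound 4 is expected to come in at 50000 nM, with a plausible range from 20000 nM to 100000 nM, and most likely to be reported once more only as the limit rather than as a number.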

Compound 4, half-maximal cytotoxic concentration: > 50000 nM
Compound 4: a limit, no number (the forecaster's own chance of this, stated with the estimate: 80%); the middle value sits exactly at the limit.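

In this assay, no step can be read from compound 1 to compound 4, since both results are limits and not numbers: the limit of > 50000 nM in this assay, at which 4 of the 4 values shown sit.

The compounds shown leave open whether any change in the aryl urea part of the shared core gives a readable number.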